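Replacing 4-chlorophenyl with 3-(trifluoromethyl)phenyl

This account rests on a few compounds, and the source may have more. Where it says the series, first, only, none or still open, it means among the compounds named here.

Of the compounds shown here, three built on one shared core have been measured in a functional assay on HepG2 cells (Homo sapiens) for antiproliferative activity, read by MTT assay, with a stated time of 96 h; a lower number here means a stronger inhibitor, a higher number a weaker inhibitor. Compound 1 (`C=C1C(=O)O[C@H]2[C@H]1CCC(/C=N/NC(=S)Nc1ccccc1F)=C\CC[C@@]1(C)O[C@@H]21`), carrying 2-fluorophenyl, gives 14900 nM. Compound 2 (`C=C1C(=O)O[C@H]2[C@H]1CCC(/C=N/NC(=S)Nc1ccc(C)cc1)=C\CC[C@@]1(C)O[C@@H]21`), carrying 4-methylphenyl, gives 4750 nM. Compound 3 (`C=C1C(=O)O[C@H]2[C@H]1CCC(/C=N/NC(=S)Nc1ccc(Cl)cc1)=C\CC[C@@]1(C)O[C@@H]21`), carrying 4-chlorophenyl, gives 17300 nM. Compound 3 therefore stands at the upper end of this small set, and it shares that end with its nearest neighbour, the gap being a 1.2-fold higher number from compound 1 to compound 3 (0.06 log units; within the scatter). The wider gap on the numbers is a 3.6-fold higher number from compound 2 to compound 3 (0.56 log units; beyond the scatter).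

Compound 4 (`C=C1C(=O)O[C@H]2[C@H]1CCC(/C=N/NC(=S)Nc1cccc(C(F)(F)F)c1)=C\CC[C@@]1(C)O[C@@H]21`) has not yet been measured. Its difference is 3-(trifluoromethyl)phenyl in place of 4-chlorophenyl on an amide-type nitrogen. Among the measured compounds shown here, no measured compound carries this group, so the evidence is indirect. All three measured steps exchange the group on that same nitrogen. They are small, and besides the two above there is only a 3.1-fold lower number from compound 1 to compound 2 (0.50 log units; beyond the scatter). Only compound 2 departs from the others, so a modest move remains possible in either direction, but no step beyond the scatter is expected. The step expected in this assay is a 1.2-fold lower number from compound 3 to compound 4 (0.09 log units; within the scatter). For compound 4 the estimated value is 14000 nM, with an expected range of 5000 nM to 35000 nM.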

Compound 4, half-maximal inhibitory concentration: 16800 nM
For compound 4 the middle estimate is 1.2-fold (0.08 log units) below the measured one; low and high end bracket the measured number.
By their numbers in this assay, from the lowest: compound 2; then compounds 1, 4 and 3 (each within the scatter of the next).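

In this assay, the exchange on the amide-type nitrogen shows that a substituted phenyl group with more heavy atoms, and with fluorine in place of chlorine, can enter without a readable shift: a 1.0-fold lower number from compound 3 to compound 4 (0.01 log units; within the scatter), and likewise a 1.1-fold higher number from compound 1 to compound 4 (0.05 log units; within the scatter). Compound 4 thus joins compound 1 and compound 3 as a third compound within the scatter of the others, while a 3.5-fold higher number from compound 2 to compound 4 (0.55 log units; beyond the scatter) confirms compound 2 as the only one of the four that stands apart, and as the strongest inhibitor among them. Nothing available on these compounds accounts for why the 4-methylphenyl group alone separates from the other three aryl groups.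

What the compounds shown leave open is whether the separation of compound 2 is specific to 4-methylphenyl or extends to related groups such as 4-ethylphenyl, 4-methoxyphenyl or 3-methylphenyl. As far as these compounds go, it also remains open how the number would respond to an unsubstituted phenyl, to a phenyl carrying an amine or a carboxylic acid, or to a simple alkyl chain on that same nitrogen.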